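One Ring Swap on the Carbonyl Carbon

This account rests on a few compounds, and the source may have more. Where it says the series, first, only, none or still open, it means among the compounds named here.

Of the compounds shown here, two with a shared core have been tested in a functional assay on NCI-H322M cells (Homo sapiens) for cytotoxicity, read by sulforhodamine B assay, with a stated time of 48 h, tested at 10 uM; on this read-out higher numbers stand for a weaker effect at the one concentration tested and lower numbers for a stronger effect. Compound 1, `COc1ccc(-c2cc(/C=C/C(=O)c3ccc(N)cc3)[nH]n2)cc1`, gives -2% in this assay. Compound 2, `COc1cc(-c2cc(/C=C/C(=O)c3ccc(Cl)c(Cl)c3)[nH]n2)cc(OC)c1OC`, gives 59% in this assay, the highest of the two numbers, and its gap from compound 1 lies beyond the usual scatter. Compound 3, `COc1ccc(C(=O)/C=C/c2cc(-c3cc(OC)c(OC)c(OC)c3)n[nH]2)cc1`, has not yet been measured. It differs from compound 2 in one place: 4-methoxyphenyl in place of 3,4-dichlorophenyl on a carbonyl carbon. No pair of measured compounds isolates exactly this change, so any expectation rests only on the two numbers shown and on the structural change itself. Compound 3 is expected to move toward a stronger effect, with a step of a number 24 percentage points lower from compound 2 to compound 3 (beyond the scatter) that is of moderate size but uncertain. Compound 3 is therefore estimated at 35%, within a range from 0% to 70%.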

Compound 3, a percentage reported as activity, at one concentration (the size of the read-out at that concentration, not a potency): -60%
For compound 3 the middle estimate is 95 percentage points above the measured one; measured number below the stated range.
By their numbers in this assay, from the lowest: compound 3; then compound 1; then compound 2.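

On the carbonyl carbon of this core, the swap of 3,4-dichlorophenyl for 4-methoxyphenyl produces, in this assay, a number 119 percentage points lower from compound 2 to compound 3 (beyond the scatter), so this single position can by itself carry a very large change in the read-out. The size of the step does not follow the heavy-atom count, which is the same for both groups; what differs is that two chlorine atoms leave while one oxygen, counted as a hydrogen-bond acceptor, enters. Nothing available here explains why this swap has so large an effect.

Still open, as far as these compounds go, is whether the step comes from losing the two chlorines, gaining the methoxy group, or both. A plain phenyl or a 4-ethoxyphenyl on the same carbonyl carbon, with the rest of compound 3 kept, would help to separate these possibilities.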